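An anilino swap in a level set of values

This account rests on a few compounds, and the source may have more. Where it says the series, first, only, none or still open, it means among the compounds named here.

Compound 1 `O=C1Nc2ccc(S(=O)(=O)N3CCOCC3)cc2/C1=N/c1cccc(C(F)(F)F)c1` gives 226000 nM in an ADME assay on WI-38 cells (Homo sapiens) for cytotoxicity, read by sulforhodamine B assay, with a stated time of 24 h; a higher number here means a weaker inhibitor, a lower number a stronger inhibitor. In the same test, compound 2 `COc1ccc(-c2c(C#N)c(N)n(/N=C3\C(=O)Nc4ccc(S(=O)(=O)N5CCOCC5)cc43)c(=O)c2C#N)cc1` gives 224000 nM and compound 3 `O=C1Nc2ccc(S(=O)(=O)N3CCOCC3)cc2/C1=N/c1ccc(/N=C2\C(=O)Nc3ccc(S(=O)(=O)N4CCOCC4)cc32)cc1` gives 203000 nM. Compound 1 therefore stands level with both, all three values lying within the usual scatter of repeated measurements.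

Compound 4 `O=C1Nc2ccc(S(=O)(=O)N3CCOCC3)cc2/C1=N/Nc1ccccc1` has not yet been measured. It departs from compound 1 in one place, with anilino in place of 3-(trifluoromethyl)phenyl on a double-bonded nitrogen.

Among the measured compounds shown here, no two measured compounds differ in only one place, so the data offer no direct guide to this change. Even so, the groups on that nitrogen differ widely among the measured compounds, yet compound 2 at 224000 nM and compound 3 at 203000 nM remain level with compound 1. No step beyond the scatter is therefore expected in this assay. The expected step is a 1.2-fold lower number from compound 1 to compound 4 (0.08 log units; within the scatter). For compound 4 the estimated value is 190000 nM, with an expected range from 80000 nM to 350000 nM.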

Compound 4, half-maximal inhibitory concentration: 262000 nM
Beside the measured number, compound 4's estimate is 1.4-fold (0.14 log units) below it; measured number inside the range.
By their numbers in this assay, from the lowest: compounds 3, 2, 1 and 4 (each within the scatter of the next).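

In this assay, among the compounds shown here, replacing 3-(trifluoromethyl)phenyl with anilino on the double-bonded nitrogen gives the first direct reading of a single change at this position: a 1.2-fold higher number from compound 1 to compound 4 (0.06 log units; within the scatter). The earlier compounds shown here could only suggest this, since none of them differed from another in one place. Here, a group with no hydrogen-bond donors or acceptors gives way to one with a donor and an acceptor, and the number stays level. No measurement shown here accounts for this outcome. The compounds shown leave open whether a carboxylic acid or a longer chain on that double-bonded nitrogen would also leave the number level in this assay. They also leave open whether the anilino swap would stay level in a different test.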